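This account rests on a few compounds, and the source may have more. Where it says the series, first, only, none or still open, it means among the compounds named here.

Measured in a functional assay on HCC827 cells (Homo sapiens) for antiproliferative activity, read by MTT assay, with a stated time of 72 h; on this read-out higher numbers stand for weaker inhibition and lower numbers for stronger inhibition:
- compound 1 `CN1CCN(c2ccc(Nc3ncc4nc(Sc5ccccc5)n(C5CCOCC5)c4n3)cc2)CC1`: 42.6 nM
- compound 2 `CN1CCN(c2ccc(Nc3ncc4nc([S+]([O-])c5ccccc5)n(CC5CC5)c4n3)cc2)CC1`: 838 nM
- compound 3 `CN1CCN(c2ccc(Nc3ncc4nc(SCc5cccnc5)n(C5CC5)c4n3)cc2)CC1`: 8830 nM

Compound 2, at 838 nM, holds the middle place of the three numbers, with compound 1 lower at 42.6 nM and compound 3 higher at 8830 nM. These three differ in more than one place, so no single change can be read from them.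

Compound 4 `CN1CCN(c2ccc(Nc3ncc4nc([S+]([O-])c5ccccc5)n(C5CCCC5)c4n3)cc2)CC1` carries cyclopentyl in place of cyclopropylmethyl on an aromatic nitrogen. For the measured compounds named here, no measured pair isolates this change, so no step beyond the scatter is expected in this assay, and the estimate stays close to compound 2 at 838 nM. The estimated change is a 1.3-fold lower number from compound 2 to compound 4 (0.11 log units; within the scatter). For compound 4 the expected value is 650 nM, with an estimated range of 200 nM to 2200 nM.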

Compound 4, half-maximal inhibitory concentration: 64.7 nM
Estimate against measurement, compound 4: 10-fold (1.00 log units) above; measured number below the stated range.
By their numbers in this assay, from the lowest: compounds 1 and 4 (each within the scatter of the next); then compound 2; then compound 3.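

For the compounds shown here, with the rest of compound 2 held fixed, cyclopentyl in place of cyclopropylmethyl on the aromatic nitrogen gives a 13-fold lower number from compound 2 to compound 4 (1.11 log units; beyond the scatter) in this assay, the first step that can be read at a single place. The earlier compounds shown here differed in more than one place and could not show that this position alone moves the number by this much. Nothing measured accounts for the step.

From the compounds shown here alone, whether cyclohexyl or a piperidine ring on this nitrogen would go further remains open. So does whether the same change gives a step of this size with the sulfur-linked group of compound 1 or compound 3.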